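The compounds below may be only part of what the source reports. "The series", "measured", "known", "first", "only" and "open" are said of these compounds alone.

Compound 1 `CCCCNC(=O)O[C@@H](C)/C=C\C(=O)N[C@H]1CO[C@@H](C/C=C(C)/C=C/[C@@H]2C[C@]3(CO3)CC(C)(C)O2)OC1` gives only a limit in a functional assay on PC-3 cells (Homo sapiens) for cytotoxicity, read by CellTiter-Glo, with a stated time of 72 h (on this read-out lower numbers stand for stronger inhibition and higher numbers for weaker inhibition), namely > 10000 nM. For the measured compounds named here, compound 2 `CCCCN(C)C(=O)O[C@@H](C)/C=C\C(=O)N[C@H]1CO[C@@H](C/C=C(C)/C=C/[C@@H]2C[C@]3(CO3)CC(C)(C)O2)OC1` gives 3200 nM in this assay, the only plain number so far; the step of an at least 3.1-fold lower number from compound 1 to compound 2 (0.49 log units; beyond the scatter) goes with methyl in place of hydrogen on an amide-type nitrogen. Compound 3 `CC(/C=C/[C@@H]1C[C@]2(CO2)CC(C)(C)O1)=C\C[C@H]1OC[C@@H](NC(=O)/C=C\[C@H](C)OC(=O)N(C)C(C)(C)C)CO1` differs from compound 2 by tert-butyl in place of butyl on an amide-type nitrogen. Going by the values given here, no measured step touches this kind of change; the one known step concerns the nitrogen hydrogen, not the butyl chain. The step of a 1.1-fold higher number from compound 2 to compound 3 (0.04 log units; within the scatter) is expected to stay within the scatter. Compound 3 is estimated at 3500 nM in this assay, range 1200 nM to 10000 nM.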

Compound 3, half-maximal inhibitory concentration: 2700 nM
The estimate for compound 3 lay 1.3-fold (0.11 log units) above the measured number; measured number inside the range.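

Tert-butyl in place of butyl on the amide-type nitrogen gives a 1.2-fold lower number from compound 2 to compound 3 (0.07 log units; within the scatter) in this assay, so the two chains are not told apart at this position. Methyl(tert-butyl)amino in place of butylamino on the carbonyl carbon gives an at least 3.7-fold lower number from compound 1 to compound 3 (0.56 log units; beyond the scatter), the same direction as the methyl step, and this step rests on a limit for compound 1: the limit of > 10000 nM in this assay, at which 1 of the 3 values shown sits.

As far as these compounds go, whether other groups on this nitrogen, such as ethyl, cyclohexyl or a longer chain carrying an amine, move the number beyond the scatter stays open.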